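Removing the ring methyl from a low-clearance azaindole amide

This account rests on a few compounds, and the source may have more. Where it says the series, first, only, none or still open, it means among the compounds named here.

Measured compounds:
- compound 1, `Cc1ccc2c(n1)c(C(=O)N[C@H]1CCOC[C@@H]1O)cn2Cc1ccc(-c2ccn(C)n2)cc1`, < 8 mL/min/kg
- compound 2, `O=C(N[C@H]1CCCC[C@@H]1O)c1cn(Cc2ccc(-n3cccn3)cc2)c2ccccc12`, 42 mL/min/kg

In an ADME assay on liver for metabolic stability, with Liver microsome (Homo sapiens) as the target, using microsomes (on this read-out lower numbers stand for slow clearance and higher numbers for fast clearance), compound 1 is reported only as a limit, < 8 mL/min/kg, so its actual clearance is not known as a number. That limit is where one of the two values sits (the limit of < 8 mL/min/kg in this assay, at which 1 of the 2 values shown sits). In this assay, within the data shown here, compound 2 gives 42 mL/min/kg, a number rather than a limit; no single-point step connects compound 2 to compound 1, so only the two values themselves can be set side by side.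

Compound 3, `Cn1ccc(-c2ccc(Cn3cc(C(=O)N[C@H]4CCOC[C@@H]4O)c4ncccc43)cc2)n1`, has not yet been measured in this assay. It differs from compound 1 by hydrogen in place of methyl on an aromatic carbon of the shared core.

Among the measured compounds shown here, with no measured step of this kind available, the account can only expect a small effect. The expected step of a number no lower from compound 1 to compound 3 (the limit leaves the size open) is none beyond the scatter of this assay. Compound 3 is therefore expected to give about 8 mL/min/kg, with a range from 4 mL/min/kg to 16 mL/min/kg, and it may well again be reported only as a limit.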

Compound 3, clearance: 10.6 mL/min/kg
Compound 3: middle estimate off by 1.3-fold (0.12 log units), on the low side; the measured number falls inside the stated range.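

Compound 3 gives the first number, 10.6 mL/min/kg, for a compound with hydrogen on this aromatic carbon next to the ring nitrogen, where the earlier compound with methyl at the same place offered no number in this assay. Hydrogen in place of methyl at this position, with the rest of the shared core and both side groups unchanged, gives an at least 1.3-fold higher number from compound 1 to compound 3 (0.12 log units; that floor lies within the scatter), so the change can now be read as a single-point step, though only from its lower end. Compound 1 is reported as a limit, and the true size of the step stays open because of it: the limit of < 8 mL/min/kg in this assay, at which 1 of the 3 values shown sits.

The compounds shown leave open how a methoxy group, a fluorine atom, an ethyl group or an amine on this same aromatic carbon would read in this assay, and whether any of them would separate from the methyl and hydrogen pair by more than the scatter. They also leave open whether the step would be the same on another core, since compound 2 differs from compound 3 in more than one place and cannot speak to it.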